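Imidazole carbon substituent change in a diphenyl series

This account rests on a few compounds, and the source may have more. Where it says the series, first, only, none or still open, it means among the compounds named here.

Compound 1 `CC(C)(C)NCCC(c1ccccc1)c1ccccc1`: 792 nM
Compound 2 `CCN(CC)CCC(c1ccccc1)c1ccccc1`: 197 nM
Compound 3 `CCc1nccn1CCC(C(N)=O)(c1ccccc1)c1ccccc1`: 78.1 nM

In an assay on ileum with muscarinic acetylcholine receptor M3 (Cavia porcellus) as the target (a higher number here means a weaker inhibitor, a lower number a stronger inhibitor), compound 3 stands lowest of the three measured numbers, with compound 2 nearest at a higher number and compound 1 furthest. Compound 4 `CC(C)(C)c1nccn1CCC(C(N)=O)(c1ccccc1)c1ccccc1` differs from compound 3 by tert-butyl in place of ethyl on an aromatic carbon. Among the measured compounds shown here, no measured step touches this ring carbon. For the measured compounds named here, the only one-place step in the set, a 4.0-fold lower number from compound 1 to compound 2 (0.60 log units; beyond the scatter), exchanges a tert-butyl-bearing amine for a diethyl one on the chain and ran toward a lower number; it bears on the present change only loosely, as the reverse exchange at an unrelated position. The change is therefore expected to give a 1.3-fold higher number from compound 3 to compound 4 (0.11 log units; within the scatter), not clearly beyond the scatter in either direction. Compound 4 is estimated at 100 nM within a range of 35 nM to 280 nM.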

Compound 4, antagonist equilibrium constant: 30.2 nM
Beside the measured number, compound 4's estimate is 3.3-fold (0.52 log units) above it; measured number below the stated range.
By their numbers in this assay, from the lowest: compound 4; then compound 3; then compound 2; then compound 1.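

In this assay, among the compounds shown here, the aromatic carbon between two ring nitrogen atoms gives the first measured step at this position: tert-butyl in place of ethyl produces a 2.6-fold lower number from compound 3 to compound 4 (0.41 log units; beyond the scatter). The series therefore accepts the larger of these two carbon groups here, and the number moves down rather than up. No data at hand give a reason for this step.

Two groups define a single step, not a trend. As far as these compounds go, whether isopropyl, methyl or plain hydrogen at this carbon would fall in line remains open.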